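The compounds below may be only part of what the source reports. "The series", "measured", "known", "first", "only" and "open" are said of these compounds alone.

Measured in a functional assay on A-431 cells (Homo sapiens) for inhibition, read by MTT assay, with a stated time of 72 h; a higher number here means a weaker inhibitor, a lower number a stronger inhibitor:
- compound 1 `O=[N+]([O-])c1ccc(-c2nnc(SCCCN3CCN(c4nc5ccccc5o4)CC3)o2)cc1`: 46900 nM
- compound 2 `Clc1ccc(-c2nnc(SCCCN3CCN(c4nc5ccccc5o4)CC3)o2)cc1`: 89600 nM
- compound 3 `CC(C)(C)Oc1ccc(-c2nnc(SCCCN3CCN(c4nc5ccccc5o4)CC3)o2)cc1`: 65800 nM

These three compounds cannot be told apart in this assay. Compound 1 lies within the scatter of both others: the data show a 1.4-fold higher number from compound 1 to compound 3 (0.15 log units; within the scatter) and a 1.9-fold higher number from compound 1 to compound 2 (0.28 log units; within the scatter). The remaining pair gives the same picture, with a 1.4-fold lower number from compound 2 to compound 3 (0.13 log units; within the scatter).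

Compound 4 `O=[N+]([O-])c1ccc(-c2nnc(SCCCN3CCN(c4nc5ccccc5s4)CC3)o2)cc1` has not yet been measured. It keeps the nitro group of compound 1 and carries 1,3-benzothiazol-2-yl in place of 1,3-benzoxazol-2-yl on an amine nitrogen in a ring.

For the measured compounds named here, none of the measured steps touches that place. All three exchange a group on an aromatic carbon, so they bear on this change only indirectly, and the data hold no direct measure of it. They show just that the three numbers sit close together when the other end of the molecule is varied. No step beyond the scatter is therefore expected, and no direction can be favoured, although the range must stay wide for an untested kind of change.

The estimated step is a 1.2-fold lower number from compound 1 to compound 4 (0.07 log units; within the scatter). For compound 4 the expected value is 40000 nM, with an estimated range from 15000 nM to 90000 nM.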

Compound 4, half-maximal inhibitory concentration: 46500 nM
Compound 4: middle estimate off by 1.2-fold (0.07 log units), on the low side, and the stated range covers the measured number.
By their numbers in this assay, from the lowest: compounds 4, 1, 3 and 2 (each within the scatter of the next).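

For the compounds shown here, the exchange of 1,3-benzoxazol-2-yl for 1,3-benzothiazol-2-yl on the amine nitrogen in the ring gives the first direct reading at this end of the molecule: in this assay there is a 1.0-fold lower number from compound 1 to compound 4 (0.00 log units; within the scatter) and the two compounds cannot be told apart. The earlier compounds shown here varied only a group on an aromatic carbon, so they could not show that sulfur in place of oxygen in the five-membered aromatic ring, with the nitro group kept and the heavy-atom count the same, gives a step within the scatter at this place. No measurement shown here bears on the reason for this result.

Going by these compounds, whether 1,3-benzothiazol-2-yl gives the same picture alongside the chloro or tert-butoxy group remains open, as this exchange has been read only with the nitro group in place. On these data alone, it is also open whether a plain phenyl or a pyridin-2-yl on that ring nitrogen, or an amine or a carboxylic acid on the aromatic carbon that now bears nitro, would move the number beyond the scatter.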